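A few compounds are considered here, and "the series" means these few. Any claim that something is new, unique, unknown or untested is made for them only; others in the source may bear on it.

In an in vitro ADME assay on microsomes from liver (Mus musculus) for metabolic stability, tested at 0.2 uM (a higher number here means faster removal of the compound, a lower number slower removal), compound 1 `Cc1c(COc2ccnc(OCC3CCOCC3)c2)[nH]c2ccccc2c1=O` gives 203 mL/min/kg. Compound 2 `Cc1c(COc2cccc(OCC3CCOCC3)c2)[nH]c2ccc(C(=O)O)cc2c1=O` reads < 50 mL/min/kg, which is a limit of the assay and not a number. This limit is the one marked in the limit of < 50 mL/min/kg in this assay, at which 1 of the 2 values shown sits. Compound 3 `Cc1c(COc2cccc(OCC3CCOCC3)c2)[nH]c2ccccc2c1=O` has hydrogen in place of carboxy on an aromatic carbon of compound 2: hydrogen in place of carboxy on an aromatic carbon. Among the measured compounds shown here, no measured pair shows this change directly, so the only guide to its size is compound 1 at 203 mL/min/kg. A large upward move, beyond the scatter, is expected, estimated as an at least 3.4-fold higher number from compound 2 to compound 3 (0.53 log units; beyond the scatter). Compound 3 is estimated at 170 mL/min/kg, with an expected range from 80 mL/min/kg to 330 mL/min/kg.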

Compound 3, clearance: 420 mL/min/kg
The estimate for compound 3 lay 2.5-fold (0.39 log units) below the measured number, outside the stated range (above it).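

In this assay, this aromatic carbon of the shared core proves highly sensitive to what it carries: hydrogen in place of carboxy gives an at least 8.4-fold higher number from compound 2 to compound 3 (0.92 log units; beyond the scatter). Compound 2 reads < 50 mL/min/kg, which is a limit of the assay and not a number. The full size of the step therefore stays unknown, and only its lower bound can be read: the limit of < 50 mL/min/kg in this assay, at which 1 of the 3 values shown sits.

Among the compounds shown here, only this one pair shows a change at this carbon. Going by these compounds, how a methyl ester, an amide or a nitrile there would read in this assay remains open.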